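Methoxypyridinyl acyl urea: solubility outlook for compound 3

The source may hold more compounds than are shown below. What is called first, only, known or untested is meant among the compounds shown, and "the series" means these compounds.

Measured so far in a physicochemical assay for solubility, in phosphate buffer, at pH 7.4; a lower number here means a less soluble compound, a higher number a more soluble compound:
compound 1 `COc1ccccc1C(=O)NC(=O)Nc1ccc(-c2ccccc2)c(C(F)(F)F)c1` — compound 1 gives < 1 ug/mL, a limit of the assay.
compound 2 `COc1ccccc1C(=O)NC(=O)Nc1ccc(N2CCCCC2)c(C(F)(F)F)c1` — compound 2 gives < 1 ug/mL, again a limit.

Compound 1 therefore stands only at a limit, and the step that the two limits leave unreadable from compound 1 to compound 2 cannot be read. Compound 3 `COc1ccncc1C(=O)NC(=O)Nc1ccc(-c2ccccc2)c(C(F)(F)F)c1` differs from compound 1 by 4-methoxypyridin-3-yl in place of 2-methoxyphenyl on a carbonyl carbon. Within the data shown here, no measured step bears on this change; the only evidence is the limit of < 1 ug/mL in this assay, at which 2 of the 2 values shown sit, so no direction is readable. For compound 3 a modest upward step an at least 2.0-fold higher number from compound 1 to compound 3 (0.30 log units; that floor lies within the scatter) is expected, giving an estimated 2 ug/mL in this assay, in the range 0.5 ug/mL to 8 ug/mL.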

Compound 3, solubility: 6.6 ug/mL
Estimate against measurement, compound 3: 3.3-fold (0.52 log units) below, within the range that was stated.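

In this assay, among these compounds, the place on the carbonyl carbon gives the only readable step so far: 4-methoxypyridin-3-yl in place of 2-methoxyphenyl brings an at least 6.6-fold higher number from compound 1 to compound 3 (0.81 log units; beyond the scatter). Among the compounds shown here, the step between the other two compounds cannot be read, so this change is the first evidence that the series can move off the limit. Its true size remains open, as only a floor can be read: the limit of < 1 ug/mL in this assay, at which 2 of the 3 values shown sit.

As far as these compounds go, whether the same change holds on the core of compound 2 remains open. Also open, from the compounds shown here alone, is how a carboxylic acid or an amine in place of the methoxy group would read.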